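A few compounds are considered here, and "the series" means these few. Any claim that something is new, unique, unknown or untested is made for them only; others in the source may bear on it.

Compounds measured:
compound 1 `COc1cc(-c2cc(/C=C/C(=O)c3ccc(N)cc3)[nH]n2)cc(OC)c1OC` — 550 nM
compound 2 `COc1ccc(-c2cc(/C=C/C(=O)c3ccc(N)cc3)[nH]n2)cc1OC` — 1740 nM
compound 3 `COc1cc(C(=O)/C=C/c2cc(-c3cc(OC)c(OC)c(OC)c3)n[nH]2)cc(OC)c1OC` — 1680 nM

In a functional assay on CCRF-CEM cells (Homo sapiens) for inhibition, read by sulforhodamine B assay, with a stated time of 48 h (a lower number here means a stronger inhibitor of growth, a higher number a weaker inhibitor of growth), compound 1 gives 550 nM, and compound 2 gives 1740 nM. Between them stands one change, (hydrogen in place of methoxy on an aromatic carbon), and it made the step of a 3.2-fold higher number from compound 1 to compound 2 (0.50 log units; beyond the scatter). The core of compound 1 is built differently from that of compound 3, and in this assay compound 3 gives 1680 nM; the difference between the two cores is not broken down here, and the values of compound 3 and compound 2 lie close to each other.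

Compound 4 `COc1ccc(-c2cc(/C=C/C(=O)c3cc(OC)c(OC)c(OC)c3)[nH]n2)cc1OC` is not yet measured. It differs from compound 3 by hydrogen in place of methoxy on an aromatic carbon, which is the same change that separates compound 1 from compound 2, at a place described in the same words. The expectation for compound 4 rests on that earlier step: because a 3.2-fold higher number from compound 1 to compound 2 (0.50 log units; beyond the scatter) was a rise, a step of similar size, a 3.0-fold higher number from compound 3 to compound 4 (0.47 log units; beyond the scatter), is estimated from compound 3 to compound 4 in this assay. Compound 4 is therefore expected to give about 5000 nM, most likely between 2000 nM and 13000 nM.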

Compound 4, concentration for 50% growth inhibition: 340 nM
For compound 4 the middle estimate is 15-fold (1.17 log units) above the measured one, and the stated range ends above it.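

In this assay, hydrogen in place of methoxy on an aromatic carbon did not repeat its earlier effect: on the core of compound 3 it gave a 4.9-fold lower number from compound 3 to compound 4 (0.69 log units; beyond the scatter), a step in the opposite direction to the one seen on the core of compound 1. The outcome of this change therefore did not carry from one core to the other in this series: the same change on two cores in this assay, a 3.2-fold higher number (0.50 log units; beyond the scatter) from compound 1 to compound 2 and a 4.9-fold lower number (0.69 log units; beyond the scatter) from compound 3 to compound 4, 16-fold (1.19 log units) apart, beyond the scatter of two such steps

Going by these compounds alone, this rests on only two pairs, so it shows that the step cannot be assumed to transfer between these two cores, but it does not show which structural difference between them reverses the direction, or how the change would behave on any further core.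

The compounds shown leave open how other replacements for methoxy at this place, such as a hydroxy group, a fluorine atom or an ethoxy group, would behave on each core. They also leave open whether removing a second methoxy group would continue either trend.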